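The compounds below may be only part of what the source reports. "The series", "measured", "known", "first", "only" and "open" are said of these compounds alone.

Measured compounds:
- compound 1, `ClCc1ccc(Cn2cnc3c(Cl)ncnc32)cc1`: in a functional assay on MCF7 cells (Homo sapiens) for cytotoxicity, read by sulforhodamine B assay, with a stated time of 48 h (a lower number here means that less compound is tolerated, a higher number that more compound is tolerated), compound 1 gives only a limit, > 100000 nM.
- compound 2, `ClCc1cccc(Cn2cnc3c(Cl)ncnc32)c1`: in this assay compound 2 gives only a limit, > 100000 nM.
- compound 3, `ClCc1ccccc1Cn1cnc2ncnc(Cl)c21`: in this assay compound 3 gives only a limit, > 100000 nM.

Compound 1 therefore does not stand at a number in this assay; it sits at the assay limit, and so do the two other compounds, since three of three values shown sit at that same limit (the limit of > 100000 nM in this assay, at which 3 of the 3 values shown sit). Within the data shown here, with every value a limit, no step between any two of the measured compounds can be sized, and nothing separates compound 1 from compound 2 or compound 3 beyond the fact that all three exceed the tested range.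

Compound 4, `ClCc1ccc(Cn2cnc3c(Cl)nc(Cl)nc32)cc1`, is the next member. Compared with compound 1 it carries chloro in place of hydrogen on an aromatic carbon, chloro in place of hydrogen on an aromatic carbon. Among the measured compounds shown here, no measured step bears on such a change. The working expectation is that no step beyond the scatter will be resolvable, because compound 1 gives a limit > 100000 nM and the same outcome is the most likely report for compound 4.

Compound 4 is expected to give about 100000 nM in this assay, within a range from 30000 nM to 300000 nM. The step expected from compound 1 to compound 4 is a number no higher from compound 1 to compound 4 (the limit leaves the size open), most probably reported again as a limit rather than a number.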

Compound 4, concentration lethal to 50% of the cells: > 100000 nM
Compound 4: only a limit was reported (the forecaster's own chance of this, stated with the estimate: 80%); the middle value lies on the limit itself.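

In this assay compound 4 gives > 100000 nM, which is a limit and not a number. No step can be read between compound 1 and compound 4, because both sit at the same limit: the limit of > 100000 nM in this assay, at which 4 of the 4 values shown sit.

The compounds shown leave open whether chloro in place of hydrogen on an aromatic carbon changes the lethal concentration at all, and how the four compounds rank.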